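The source may hold more compounds than are shown below. What is called first, only, known or untested is meant among the compounds shown, and "the series" means these compounds.

Measured in a toxicity assay on KB cells (Homo sapiens) for cytotoxicity, read by fluorescence, with a stated time of 3 days; on this read-out lower numbers stand for an effect already at smaller amounts and higher numbers for an effect only at larger amounts of compound:
- compound 1 `CCCCOC(=O)CNC(=O)[C@H](CSc1ccc([N+](=O)[O-])cc1[N+](=O)[O-])NC(=O)CC[C@H](NC(=O)OC(C)(C)C)C(=O)OCCCC`: 70.4 uM
- compound 2 `CCCCOC(=O)CNC(=O)[C@H](CSc1ccc([N+](=O)[O-])cc1[N+](=O)[O-])NC(=O)CC[C@H](NC(=O)/C=C/c1ccccc1)C(=O)OCCCC`: 34.4 uM

Of these two numbers, compound 2 holds the lower, at 34.4 uM, so it stands at the low end of this small set. The next structure, compound 3 `CCCCOC(=O)CNC(=O)[C@H](CSc1ccc([N+](=O)[O-])cc1[N+](=O)[O-])NC(=O)CC[C@H](N)C(=O)OCCCC`, has not yet been measured. It departs from compound 2 as follows: hydrogen in place of (2-phenylethenyl)carbonyl on an amine nitrogen. In short, hydrogen takes the place of (2-phenylethenyl)carbonyl on an amine nitrogen.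

Among the measured compounds shown here, only one measured step bears on this change: a 2.0-fold lower number from compound 1 to compound 2 (0.31 log units; beyond the scatter). That step is modest, and it swaps tert-butoxy for 2-phenylethenyl on a carbonyl carbon rather than removing the whole acyl group. For the measured compounds named here, no measured compound carries the free amino group, so the evidence is indirect. A step of similar modest size is therefore expected in this assay, towards a higher number, with a result within the scatter of compound 2 remaining possible. The expected change is a 1.5-fold higher number from compound 2 to compound 3 (0.16 log units; within the scatter). For compound 3 the value is estimated at 50 uM, with an expected range from 20 uM to 120 uM.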

Compound 3, concentration for half-maximal effect: 107 uM
Estimate against measurement, compound 3: 2.1-fold (0.33 log units) below, and the stated range covers the measured number.
By their numbers in this assay, from the lowest: compound 2; then compounds 1 and 3 (each within the scatter of the next).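

In this assay, taking the whole (2-phenylethenyl)carbonyl off the amine nitrogen gives a 3.1-fold higher number from compound 2 to compound 3 (0.49 log units; beyond the scatter), so this group on this nitrogen is now seen against the free amino group, and the step lies beyond the scatter. Taking off tert-butoxycarbonyl at the same nitrogen gives a 1.5-fold higher number from compound 1 to compound 3 (0.18 log units; within the scatter), which lies within the scatter, so the free amino group and tert-butoxycarbonyl cannot be told apart here, and among these three substituents only (2-phenylethenyl)carbonyl stands apart from the others. No measurement is at hand that would account for these differences in terms of a mechanism.

The compounds shown leave open which part of (2-phenylethenyl)carbonyl matters, the aromatic ring or the double bond, since neither a 3-phenylpropanoyl group, which keeps the ring without the double bond, nor a small acetyl group on this nitrogen is among them. They also leave open whether the same order of these groups would hold with a carboxylic acid in place of the butyl esters, or with a longer chain on those esters.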